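Removing a Methyl From the Phenol Oxygen

The compounds below may be only part of what the source reports. "The series", "measured", "known", "first", "only" and "open" are said of these compounds alone.

Of the compounds shown here, two have been measured in a functional assay on SK-MEL-5 cells (Homo sapiens) for inhibition, read by sulforhodamine B assay, with a stated time of 48 h; on this read-out higher numbers stand for weaker inhibition of growth and lower numbers for stronger inhibition of growth. Compound 1 `O=C(Nc1cccc(-n2cc(-c3ccncc3)c(-c3ccc(Cl)c(O)c3)n2)c1)Nc1cccc(C(F)(F)F)c1` carries a hydroxy group on one of its aromatic rings and a trifluoromethyl-bearing ring on its urea; in this assay compound 1 gives 4710 nM. Compound 2 `COc1cc(-c2nn(-c3cccc(NC(=O)Nc4ccc(Cl)c(C(F)(F)F)c4)c3)cc2-c2ccncc2)ccc1Cl` carries a methoxy group in the corresponding place and a chloro group next to the trifluoromethyl on its urea ring; in this assay compound 2 gives 2890 nM. The two numbers lie within the usual scatter of each other, so compound 2 stands alongside compound 1 rather than apart from it.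

Compound 3 `O=C(Nc1cccc(-n2cc(-c3ccncc3)c(-c3ccc(Cl)c(O)c3)n2)c1)Nc1ccc(Cl)c(C(F)(F)F)c1` is not yet measured. It differs from compound 2 by hydrogen in place of methyl on an oxygen on an aromatic ring, and thus pairs the hydroxy group of compound 1 with the urea ring of compound 2. Within the data shown here, no single-change step between measured compounds is available to guide this. Since compound 1 with its hydroxy group gives 4710 nM and compound 2 gives 2890 nM, the change is expected to move the number little, giving a step of about a 1.2-fold higher number from compound 2 to compound 3 (0.08 log units; within the scatter), not clearly beyond the scatter. Compound 3 is therefore estimated at 3500 nM, with a range from 1200 nM to 10000 nM.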

Compound 3, concentration for total growth inhibition: 1080 nM
Beside the measured number, compound 3's estimate is 3.2-fold (0.51 log units) above it; measured number below the stated range.
By their numbers in this assay, from the lowest: compound 3; then compounds 2 and 1 (each within the scatter of the next).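

In this assay, methoxy to hydroxy on the 4-chloro-3-hydroxyphenyl ring gives a 2.7-fold lower number from compound 2 to compound 3 (0.43 log units; beyond the scatter), a modest step that shows this oxygen is sensitive to whether it carries a methyl or a hydrogen, at least with this urea ring. Chloro in place of hydrogen on an aromatic carbon of the urea ring gives a 4.4-fold lower number from compound 1 to compound 3 (0.64 log units; beyond the scatter), also modest, so with the hydroxy group in place this second site matters too. No measurement shown here explains either step.

The compounds shown leave open whether the step from methoxy to hydroxy has the same size on a urea ring without the chloro group. They also leave open how an amine or a longer ether chain would compare with hydroxy at this place.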